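This account rests on a few compounds, and the source may have more. Where it says the series, first, only, none or still open, it means among the compounds named here.

Measured in a functional assay on HepG2 cells (Homo sapiens) for antiproliferative activity, read by CCK-8 assay, with a stated time of 48 h; on this read-out lower numbers stand for stronger inhibition and higher numbers for weaker inhibition:
- compound 1 `COc1ccc(/C=C\c2cc(OC)c(OC)c(OC)c2)cc1OCc1ccc(CNCCO)cc1`: 5900 nM
- compound 2 `COc1ccc(/C=C\c2cc(OC)c(OC)c(OC)c2)cc1OCc1ccc(CN2CC(C(=O)O)C2)cc1`: > 10000 nM

Compound 2 gives only a limit and no number, > 10000 nM.

Next in the series is compound 3 `COc1ccc(/C=C\c2cc(OC)c(OC)c(OC)c2)cc1OCc1ccc(CNCCNC(C)=O)cc1`, not yet measured. It keeps the shared core and changes one group on a saturated chain carbon bound to an aromatic carbon, where (2-acetamidoethyl)amino takes the place of 3-carboxyazetidin-1-yl: (2-acetamidoethyl)amino in place of 3-carboxyazetidin-1-yl on a saturated chain carbon bound to an aromatic carbon.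

Within the data shown here, one measured step bears on this, at the same place: an at least 1.6-fold higher number from compound 1 to compound 2 (0.22 log units; that floor lies within the scatter). That step brought in the 3-carboxyazetidin-1-yl group in place of (2-hydroxyethyl)amino, and the change to compound 3 removes that group again in favour of another open chain without a ring. With only compound 1 at 5900 nM as a numeric guide, the direction expected in this assay is weakly towards a lower number, with no step beyond the scatter.

The expected step is an at least 1.4-fold lower number from compound 2 to compound 3 (0.15 log units; that floor lies within the scatter).

For compound 3 the estimate is 7000 nM, with an expected range from 2500 nM to 20000 nM.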

Compound 3, half-maximal inhibitory concentration: 6100 nM
The estimate for compound 3 lay 1.1-fold (0.06 log units) above the measured number; the range from low to high includes it.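

In this assay, the change of hydroxy to acetamido on a saturated chain carbon, two bonds along the chain from an amine nitrogen, gives a 1.0-fold higher number from compound 1 to compound 3 (0.01 log units; within the scatter), so compound 1 and compound 3 cannot be told apart and this position takes either open chain with no readable difference. Replacing 3-carboxyazetidin-1-yl with (2-acetamidoethyl)amino gives an at least 1.6-fold lower number from compound 2 to compound 3 (0.21 log units; that floor lies within the scatter), which fixes only a floor for the size of the step and gives no measured gap between the two groups. Compound 2 carries a limit and not a number, so any comparison with it remains open-ended: the limit of > 10000 nM in this assay, at which 1 of the 3 values shown sits.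

The compounds shown leave open whether the four-membered ring or the carboxylic acid of 3-carboxyazetidin-1-yl goes with the limit of compound 2, since the two come and go together in every comparison here. An open chain ending in a carboxylic acid, set against a four-membered ring bearing a hydroxy group, would separate the two, and a longer chain would test how far the open-chain result extends.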